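Compound 3 and a swap of its halogenated phenyl group

The source may report more compounds than this note shows. Statements on the series, on what has been measured and on what is new or still open speak of the compounds shown alone.

In a functional assay on HL-60 cells (Homo sapiens) for inhibition, read by MTT assay, with a stated time of 48 h, tested at 10 uM (a higher number here means more inhibition of growth at the concentration tested, a lower number less inhibition of growth), compound 1 `Cc1oc2c([C@H]3CCN(C)C[C@H]3O)c(O)cc(O)c2c(=O)c1C(O)c1ccc(Cl)cc1` gives 2% while compound 2 `Cc1oc2c([C@H]3CCN(C)C[C@H]3O)c(O)cc(O)c2c(=O)c1C(O)c1cccc(Cl)c1` gives 22% and compound 3 `Cc1oc2c([C@H]3CCN(C)C[C@H]3O)c(O)cc(O)c2c(=O)c1C(O)c1ccc(F)c(Br)c1` gives 25% on this scale. The numbers show a number 3 percentage points higher from compound 2 to compound 3 (within the scatter) and a number 23 percentage points higher from compound 1 to compound 3 (beyond the scatter) so compound 3 stands level with compound 2 and clear of compound 1.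

Compound 4 `Cc1oc2c([C@H]3CCN(C)C[C@H]3O)c(O)cc(O)c2c(=O)c1C(O)c1c(F)cccc1Cl` changes one thing, 2-chloro-6-fluorophenyl in place of 3-bromo-4-fluorophenyl on a saturated chain carbon bound to an aromatic carbon and an oxygen on a saturated carbon on a saturated chain carbon bound to an aromatic carbon and an oxygen on a saturated carbon: 2-chloro-6-fluorophenyl in place of 3-bromo-4-fluorophenyl.

All three measured steps swap this same group, and a number 20 percentage points higher from compound 1 to compound 2 (beyond the scatter) is the remaining one, so such swaps can matter. Within the data shown here, no measured compound carries 2-chloro-6-fluorophenyl, which leaves the direction uncertain. A modest fall is expected, and the estimated move is a number 11 percentage points lower from compound 3 to compound 4 (beyond the scatter) with wide uncertainty. Compound 4 is estimated at 14% with an expected range from 1% to 32% on the same scale.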

Compound 4, percent growth inhibition at one concentration: 49%
For compound 4 the middle estimate is 35 percentage points below the measured one; measured number above the stated range.
By their numbers in this assay, from the lowest: compound 1; then compounds 2 and 3 (each within the scatter of the next); then compound 4.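

In this assay, placing 2-chloro-6-fluorophenyl on this saturated chain carbon gives a number 24 percentage points higher from compound 3 to compound 4 (beyond the scatter) and a number 27 percentage points higher from compound 2 to compound 4 (beyond the scatter) and a number 47 percentage points higher from compound 1 to compound 4 (beyond the scatter). Compound 2 and compound 3 stand level, so the earlier swaps alone gave no sign that this position could go higher, even though the entering group has the same heavy-atom count as 3-bromo-4-fluorophenyl. Nothing measured here gives a reason for this rise.

On these data alone, whether the gain needs both the chlorine and the fluorine remains open. So does the outcome with an unsubstituted phenyl, or with a methoxy or amine group on the ring.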